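The compounds below may be only part of what the source reports. "The series", "measured", "known", "first", "only" and "open" are said of these compounds alone.

Compound 3 `CCNC(=O)Nc1ccc(S(=O)(=O)Oc2ccccc2C)cc1` gives the lowest number of the three in a functional assay on MCF7 cells (Homo sapiens) for cytotoxicity, read by sulforhodamine B assay, with a stated time of 48 h (on this read-out lower numbers stand for stronger inhibition and higher numbers for weaker inhibition), with 4500 nM; compound 2 `CCc1ccccc1OS(=O)(=O)c1ccc(NC(=O)NCCCCl)cc1` gives 15000 nM and compound 1 `Cc1ccccc1OS(=O)(=O)c1ccc(NC(=O)NCCCCl)cc1` gives 27000 nM, both beyond the scatter from compound 3. Compound 4 `CCNC(=O)Nc1ccc(S(=O)(=O)Oc2ccccc2CC)cc1` differs from compound 3 by methyl in place of hydrogen on a saturated chain carbon bound to an aromatic carbon. The same change has been measured once in the series, where a 1.8-fold lower number from compound 1 to compound 2 (0.26 log units; within the scatter). The other measured step, a 6.0-fold lower number from compound 1 to compound 3 (0.78 log units; beyond the scatter), alters a different part of the molecule and does not bear on this change. On that single precedent no step beyond the scatter is expected, at most a slight lowering of the number. For compound 4 in this assay the estimate is 3000 nM, with a range of 1300 nM to 7000 nM, corresponding to an expected 1.5-fold lower number from compound 3 to compound 4 (0.18 log units; within the scatter).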

Compound 4, half-maximal inhibitory concentration: 3400 nM
Beside the measured number, compound 4's estimate is 1.1-fold (0.05 log units) below it, within the range that was stated.
By their numbers in this assay, from the lowest: compounds 4 and 3 (each within the scatter of the next); then compounds 2 and 1 (each within the scatter of the next).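

The change from 2-methylphenyl to 2-ethylphenyl now stands on two cores in this assay, and a 1.3-fold lower number from compound 3 to compound 4 (0.12 log units; within the scatter) remains as small as the earlier step: the same change on two cores in this assay, a 1.8-fold lower number (0.26 log units; within the scatter) from compound 1 to compound 2 and a 1.3-fold lower number (0.12 log units; within the scatter) from compound 3 to compound 4, 1.4-fold (0.13 log units) apart, within the scatter of two such steps. Hydrogen in place of chloromethyl, on a saturated chain carbon two bonds along the chain from an amide-type nitrogen, also repeats with the ethyl group present, as a 4.4-fold lower number from compound 2 to compound 4 (0.64 log units; beyond the scatter): the same change on two cores in this assay, a 6.0-fold lower number (0.78 log units; beyond the scatter) from compound 1 to compound 3 and a 4.4-fold lower number (0.64 log units; beyond the scatter) from compound 2 to compound 4, 1.4-fold (0.13 log units) apart, within the scatter of two such steps. Across these four compounds, the two changes read independently of each other.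

From the compounds shown here alone, whether a propyl chain or an amine in place of that ethyl group would give a step beyond the scatter remains open. So does the effect of a hydroxyl group in place of the chloromethyl.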